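The source may hold more compounds than are shown below. What is called first, only, known or untested is meant among the compounds shown, and "the series" means these compounds.

Compound 1 `COc1ccc(-c2cc(C(=O)Nc3ccc(Oc4ccnc5cc(OCCCN6CCCCC6)c(OC)cc45)c(F)c3)c3ccccc3n2)cc1` was tested in a functional assay on MKN-45 cells (Homo sapiens) for cytotoxicity, read by MTT assay, with a stated time of 72 h (a higher number here means a weaker inhibitor, a lower number a stronger inhibitor), where compound 1 gives 210 nM. Among the three measured compounds that number is the second highest. Compound 3 `COc1ccc(-c2cc(C(=O)Nc3ccc(Oc4ccnc5cc(OCCCN6CCC(C)CC6)c(OC)cc45)c(F)c3)c3ccccc3n2)cc1` gives 320 nM, and the step of a 1.5-fold higher number from compound 1 to compound 3 (0.18 log units; within the scatter) stays within the scatter. Compound 2 `COc1cc2c(Oc3ccc(NC(=O)c4cc(-c5ccc(F)cc5)nc5ccccc45)cc3F)ccnc2cc1OCCCN1CCCCC1` gives 28 nM, and the step of a 7.5-fold lower number from compound 1 to compound 2 (0.88 log units; beyond the scatter) lies beyond the scatter. Compound 4 `COc1ccc(-c2cc(C(=O)Nc3ccc(Oc4ccnc5cc(OCCCN6CCCCC6)c(OC)cc45)c(F)c3)c3cc(F)ccc3n2)cc1` differs from compound 1 by fluoro in place of hydrogen on an aromatic carbon. Neither measured step matches this change closely: in compound 2 the fluoro enters in place of a methoxy elsewhere, and compound 3 changes a saturated ring. Since the step of a 1.5-fold higher number from compound 1 to compound 3 (0.18 log units; within the scatter) shows a small change at another place staying within the scatter, compound 4 is expected to show a 1.2-fold lower number from compound 1 to compound 4 (0.09 log units; within the scatter). Compound 4 is therefore estimated at 170 nM, with a range from 70 nM to 420 nM.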

Compound 4, half-maximal inhibitory concentration: 260 nM
For compound 4 the middle estimate is 1.5-fold (0.18 log units) below the measured one; measured number inside the range.
By their numbers in this assay, from the lowest: compound 2; then compounds 1, 4 and 3 (each within the scatter of the next).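

In this assay, fluoro in place of hydrogen on this aromatic carbon gives a 1.2-fold higher number from compound 1 to compound 4 (0.09 log units; within the scatter), so at this position the change cannot be told apart from repeat-measurement scatter. This single fluoro does not repeat the larger step seen when fluoro replaced methoxy at another place, a 7.5-fold lower number from compound 1 to compound 2 (0.88 log units; beyond the scatter). Nothing available here explains either result. Still open, from the compounds shown here alone, is whether a chlorine, a nitrile or an amine on this same carbon would also stay within the scatter, and whether fluoro on the other carbons of this ring would behave the same way.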